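Compound 2 to Compound 3: Isopropyl for Methyl

The source may report more compounds than this note shows. Statements on the series, on what has been measured and on what is new or still open speak of the compounds shown alone.

The study measures inhibition in an assay on BT-549 cells for inhibition of Tryptophan 2,3-dioxygenase (Homo sapiens); a higher number here means a weaker inhibitor, a lower number a stronger inhibitor. Compound 1 `CC1=C(CC(=O)c2sccc2Br)C(=O)c2ccccc2C1=O` gives 3.42 nM in this assay. Compound 2 `COc1ccccc1C(=O)CC(=O)c1ccc(C)cc1O` gives 20600 nM in this assay. For the measured compounds named here, of the two numbers so far, compound 2 stands at the higher one, and its gap to compound 1 lies far beyond the scatter of repeated measurements. Going by the values given here, no pair that differs in a single place has been measured, so the two values show only that compound 2 is the weaker inhibitor of the pair.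

Compound 3 `Cc1ccc(C(=O)CC(=O)c2ccccc2OC(C)C)c(O)c1` has not been measured. It differs from compound 2 in one place: isopropyl in place of methyl on an oxygen on an aromatic ring. Cut one bond further out, the same change reads methoxy to isopropoxy. Among the compounds with values here, no measured step of this kind exists here, and the two values give no ground for predicting a large move. Compound 3 is therefore expected to stay close to compound 2, and the expected step of a 1.4-fold lower number from compound 2 to compound 3 (0.14 log units; within the scatter) is small and in no firm direction. For compound 3 the estimate in this assay is 15000 nM, with a range from 4000 nM to 60000 nM.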

Compound 3, half-maximal inhibitory concentration: 10800 nM
Beside the measured number, compound 3's estimate is 1.4-fold (0.14 log units) above it; low and high end bracket the measured number.
By their numbers in this assay, from the lowest: compound 1; then compounds 3 and 2 (each within the scatter of the next).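

For the compounds shown here, this is the first step in the account that changes only one place, and so the first direct reading of the group on an oxygen on an aromatic ring: in this assay, isopropyl in place of methyl gives a 1.9-fold lower number from compound 2 to compound 3 (0.28 log units; within the scatter) and so stays within the scatter of repeated measurements. Methoxy and isopropoxy therefore cannot be told apart at this position, even though the entering group has 3 heavy atoms where the leaving group has 1. Nothing available explains this outcome. Going by these compounds alone, the single step shows only that this one exchange leaves the read-out within the scatter, and it cannot be extended to other groups.

Going by these compounds, both groups compared here are small alkyl groups on that oxygen, so it remains open how a free hydroxyl, a longer chain such as butoxy, or a chain ending in an amine or a carboxylic acid would read there. On these data alone, it also remains open which differences separate these two compounds from compound 1, which differs from them in more than one place.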